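The compounds below may be only part of what the source reports. "The series", "measured", "known", "first", "only" and "open" are said of these compounds alone.

Compound 1 `Cc1nn(C)c(-n2ccnc2)c1/C=N/OCc1ccc(C(=O)OC(C)(C)C)cc1` is the stronger of the two compounds measured in a functional assay on SK-MEL-2 cells (Homo sapiens) for cytotoxicity (on this read-out lower numbers stand for stronger inhibition and higher numbers for weaker inhibition), where compound 1 gives 9.35 ug/mL. Within the data shown here, compound 2 `Cc1nn(C)c(-n2cccn2)c1/C=N/OCc1ccc(C(=O)OC(C)(C)C)cc1` gives 28.8 ug/mL in this assay, and the step of a 3.1-fold higher number from compound 1 to compound 2 (0.49 log units; beyond the scatter) is the only measured change at this carbon. Compound 3 `Cc1nn(C)c(N(C)C)c1/C=N/OCc1ccc(C(=O)OC(C)(C)C)cc1` differs from compound 1 by dimethylamino in place of 1H-imidazol-1-yl on an aromatic carbon. Among the measured compounds shown here, the one relevant step, from compound 1 to compound 2, shows that replacing the 1H-imidazol-1-yl costs potency modestly; a ring-free dimethylamino is a further departure, so a modest weakening is expected, a 2.1-fold higher number from compound 1 to compound 3 (0.33 log units; beyond the scatter). The estimate for compound 3 in this assay is 20 ug/mL, with a range from 6 ug/mL to 60 ug/mL.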

Compound 3, half-maximal inhibitory concentration: 23.9 ug/mL
The estimate for compound 3 lay 1.2-fold (0.08 log units) below the measured number; measured number inside the range.
By their numbers in this assay, from the lowest: compound 1; then compounds 3 and 2 (each within the scatter of the next).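

In this assay, the ring-free dimethylamino also gives a weaker result than the 1H-imidazol-1-yl (a 2.6-fold higher number from compound 1 to compound 3 (0.41 log units; beyond the scatter)), so the 1H-pyrazol-1-yl is not the only replacement at this aromatic carbon that costs potency. Dimethylamino and 1H-pyrazol-1-yl cannot be told apart (a 1.2-fold lower number from compound 2 to compound 3 (0.08 log units; within the scatter)), so among these three groups only the 1H-imidazol-1-yl stands apart, and having a five-membered aromatic ring there is not enough to match it. Nothing available explains this result. As far as these compounds go, whether a 1H-1,2,4-triazol-1-yl or a morpholin-4-yl group at this carbon would match compound 1 or compound 3 remains open.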